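Replacing 4-chlorophenyl with 1H-benzimidazol-2-yl on an aromatic nitrogen

The compounds below may be only part of what the source reports. "The series", "measured", "known", "first", "only" and "open" are said of these compounds alone.

Of the compounds shown here, three sharing one core have been measured in a functional assay on MCF7 cells (Homo sapiens) for cytotoxicity, read by sulforhodamine B assay, with a stated time of 48 h; on this read-out lower numbers stand for stronger inhibition and higher numbers for weaker inhibition. Compound 1 (`Nc1c(-c2nc3ccccc3[nH]2)cc(-c2ccccc2)n1-c1ccncc1`) gives 705 nM, compound 2 (`Nc1c(-c2nc3ccccc3[nH]2)cc(-c2ccccc2)n1-c1cccc(Cl)c1`) gives 1700 nM, and compound 3 (`Nc1c(-c2nc3ccccc3[nH]2)cc(-c2ccccc2)n1-c1ccc(Cl)cc1`) gives 934 nM. The number for compound 3 falls between the other two, but it is separated from neither beyond the scatter: the steps are a 1.3-fold higher number from compound 1 to compound 3 (0.12 log units; within the scatter) and a 1.8-fold lower number from compound 2 to compound 3 (0.26 log units; within the scatter).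

Compound 4 (`Nc1c(-c2nc3ccccc3[nH]2)cc(-c2ccccc2)n1-c1nc2ccccc2[nH]1`) carries 1H-benzimidazol-2-yl in place of 4-chlorophenyl on an aromatic nitrogen. The three measured steps all change the group at this same nitrogen, although none of them introduces a group of this kind. The largest of them is a 2.4-fold higher number from compound 1 to compound 2 (0.38 log units; beyond the scatter), so no step beyond the scatter is expected here, and the data favour neither direction. Compound 4 is expected to give about 800 nM. The expected range for compound 4 runs from 250 nM to 2600 nM. This estimate corresponds to a 1.2-fold lower number from compound 3 to compound 4 (0.07 log units; within the scatter).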

Compound 4, half-maximal inhibitory concentration: 1620 nM
Beside the measured number, compound 4's estimate is 2.0-fold (0.31 log units) below it; the range from low to high includes it.
By their numbers in this assay, from the lowest: compounds 1, 3, 4 and 2 (each within the scatter of the next, the first and the last beyond it).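

In this assay, 1H-benzimidazol-2-yl brings a five-membered aromatic ring with 2 hetero atoms and a hydrogen-bond donor to this aromatic nitrogen, yet compound 4 stays within the scatter of both chlorophenyl compounds (a 1.7-fold higher number from compound 3 to compound 4 (0.24 log units; within the scatter)) (a 1.0-fold lower number from compound 2 to compound 4 (0.02 log units; within the scatter)). Only compound 1, with pyridin-4-yl, stands apart from compound 4 (a 2.3-fold higher number from compound 1 to compound 4 (0.36 log units; beyond the scatter)), a modest step that makes compound 1 separate beyond the scatter from compound 2 and compound 4, but not from compound 3. No measurement shown here accounts for these numbers.

All four groups at this nitrogen are aromatic, so a saturated amine such as piperidin-4-yl or an open alkyl chain remains an open case. Also open, on these data alone, is how a carboxylic acid on the nitrogen-bound phenyl ring, or a replacement of the amino group, would read.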